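Sulfur for selenium: expectation for compound 4

A few compounds are considered here, and "the series" means these few. Any claim that something is new, unique, unknown or untested is made for them only; others in the source may bear on it.

Measured so far:
compound 1, `CS/C(=N\C(=O)c1cc(-c2ccccc2)nc2ccccc12)NC(=O)c1cc(-c2ccccc2)nc2ccccc12`: in a functional assay on HT-29 cells (Homo sapiens) for cytotoxicity, read by MTT assay, with a stated time of 72 h (on this read-out higher numbers stand for weaker inhibition of growth and lower numbers for stronger inhibition of growth), compound 1 gives > 100000 nM, which is a limit of the assay.
compound 2, `C[Se]/C(=N\C(=O)c1cc(-c2ccccc2)nc2ccccc12)NC(=O)c1cc(-c2ccccc2)nc2ccccc12`: in this assay compound 2 gives 90700 nM.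
compound 3, `C[Se]/C(=N\C(=O)c1cnc2ccccc2c1)NC(=O)c1cnc2ccccc2c1`: in this assay compound 3 gives > 100000 nM, which is a limit of the assay.

For the measured compounds named here, the one measured step is a group of 2 heavy atoms (1 carbon, 1 sulfur; no ring) in place of a group of 2 heavy atoms (1 carbon, 1 selenium; no ring), on a carbon with a double bond to nitrogen. It gives an at least 1.1-fold higher number from compound 2 to compound 1 (0.04 log units; that floor lies within the scatter), and its size is bounded by the limit of > 100000 nM in this assay, at which 2 of the 3 values shown sit. How the core of compound 2 and the core of compound 3 differ is not broken down here.

Compound 4, `CS/C(=N\C(=O)c1cnc2ccccc2c1)NC(=O)c1cnc2ccccc2c1`, is not yet measured. It differs from compound 3 by a group of 2 heavy atoms (1 carbon, 1 sulfur; no ring) in place of a group of 2 heavy atoms (1 carbon, 1 selenium; no ring), on a carbon with a double bond to nitrogen; the place is the same as in the step from compound 2 to compound 1, so this is the same change.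

Compound 3 already sits at a limit, and the same change on compound 2 moved the number no further than an at least 1.1-fold higher number from compound 2 to compound 1 (0.04 log units; that floor lies within the scatter). Compound 4 is therefore expected at 150000 nM, between 60000 nM and 400000 nM, most likely reported as a limit. The expected step is a step that the limit leaves unreadable from compound 3 to compound 4.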

Compound 4, concentration for total growth inhibition: > 100000 nM
Compound 4 was reported as a limit (the forecaster's own chance of this, stated with the estimate: 85%); the middle value lies beyond the limit too.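

Compound 3 and compound 4 are both reported only as limits in this assay, so no step can be read between them: the limit of > 100000 nM in this assay, at which 3 of the 4 values shown sit.

The compounds shown leave open whether methylsulfanyl in place of its selenium counterpart changes growth inhibition on the core of compound 3 at all, and in which direction.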